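This account rests on a few compounds, and the source may have more. Where it says the series, first, only, none or still open, it means among the compounds named here.

Measured so far in a physicochemical assay for lipophilicity, using the shake flask method; on this read-out lower numbers stand for lower lipophilicity and higher numbers for higher lipophilicity:
- compound 1 `Cc1ccc(NC(=O)c2cc(Oc3ccc(S(C)(=O)=O)cc3)cc(OC(C)C)c2)nc1`: 4.05
- compound 2 `CC(C)Oc1cc(Oc2ccc(S(C)(=O)=O)cc2)cc(-c2cccc(=O)[nH]2)c1`: 2.82
- compound 3 `CC(C)Oc1cc(Oc2ccc(S(C)(=O)=O)cc2)cc(-c2nccc(=O)[nH]2)c1`: 2.14

Of these three, compound 3 gives the lowest number, 2.14. The next structure is compound 4 `Cc1cc(=O)[nH]c(-c2cc(Oc3ccc(S(C)(=O)=O)cc3)cc(OC(C)C)c2)n1`, which has not been measured yet. It differs from compound 3 as follows: methyl in place of hydrogen on an aromatic carbon. In words, this is methyl in place of hydrogen on an aromatic carbon.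

For the measured compounds named here, no measured step makes this exact change, so the evidence is indirect. All three measured steps swap the whole ring-bearing group on the shared core. Two are large, a number 1.23 log units lower from compound 1 to compound 2 (beyond the scatter) and a number 1.91 log units lower from compound 1 to compound 3 (beyond the scatter), and one is modest, a number 0.68 log units lower from compound 2 to compound 3 (beyond the scatter). Across these three compounds, the fewer carbon atoms that group holds, the lower the number, and none goes against this. The methyl adds carbon to that group, so a small rise in this assay is expected, smaller than a number 0.68 log units lower from compound 2 to compound 3 (beyond the scatter). The expected change is a number 0.36 log units higher from compound 3 to compound 4 (beyond the scatter). For compound 4 the estimated value is 2.5, with an expected range from 2.2 to 2.9.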

Compound 4, distribution coefficient: 2.43
Estimate against measurement, compound 4: 0.07 log units above; the measured number falls inside the stated range.
By their numbers in this assay, from the lowest: compounds 3 and 4 (each within the scatter of the next); then compound 2; then compound 1.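

In this assay, methyl in place of hydrogen on this aromatic carbon, next to the ring nitrogen, gives a number 0.29 log units higher from compound 3 to compound 4 (within the scatter) and so leaves the two compounds unseparated. The groups compared in a number 0.39 log units lower from compound 2 to compound 4 (beyond the scatter) hold the same count of carbon, so carbon count alone does not set the order among these compounds, while a number 1.62 log units lower from compound 1 to compound 4 (beyond the scatter) keeps the group of 10 heavy atoms apart from the smaller one. No measurement here explains why these steps take the sizes they do.

As far as these compounds go, whether a longer chain such as ethyl, an amine or a carboxylic acid on this same aromatic carbon would move the number beyond the scatter stays open. Also open, from the compounds shown here alone, is whether methyl on the ring of compound 2 would give a step of similar size.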